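Compound 1 to compound 4: one more chloro

This account rests on a few compounds, and the source may have more. Where it says the series, first, only, none or still open, it means among the compounds named here.

Measured so far in a functional assay on HepG2 cells (Homo sapiens) for antiproliferative activity, read by MTT assay, with a stated time of 72 h; a higher number here means a weaker inhibitor, a lower number a stronger inhibitor:
compound 1 `COc1cc(CCc2ccccc2Cl)cc(OC)c1O` gives 2190 nM
compound 2 `COc1cc(CCc2ccccc2F)cc(OC)c1O` gives 1030 nM
compound 3 `COc1cc(CCc2cccc(Cl)c2Cl)cc(OC)c1O` gives 4770 nM

Compound 1 holds the second highest of these three numbers, and its steps to the other two compounds run in opposite directions. Compound 4 `COc1cc(CCc2ccc(Cl)cc2Cl)cc(OC)c1O` has not yet been measured. Its difference from compound 1 is chloro in place of hydrogen on an aromatic carbon and the new chloro sits on an aromatic carbon, meta to a chloro group and para to a large group.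

The measured step of the same kind is a 2.2-fold higher number from compound 1 to compound 3 (0.34 log units; beyond the scatter) and it is modest, though beyond the scatter. The other measured step, a 2.1-fold lower number from compound 1 to compound 2 (0.33 log units; beyond the scatter), exchanges one halogen for another, so it bears on the present change only indirectly. It is also modest. The data do not show whether the first step keeps its size at the new place. A modest rise in the number is therefore expected in this assay, although a step within the scatter remains possible. The expected change is a 1.6-fold higher number from compound 1 to compound 4 (0.20 log units; within the scatter) on this reasoning. For compound 4 the estimated value is 3500 nM, with an expected range from 1500 nM to 8000 nM.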

Compound 4, half-maximal inhibitory concentration: 6740 nM
Beside the measured number, compound 4's estimate is 1.9-fold (0.28 log units) below it, and the stated range covers the measured number.
By their numbers in this assay, from the lowest: compound 2; then compound 1; then compounds 3 and 4 (each within the scatter of the next).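

In this assay, chloro in place of hydrogen on the aromatic carbon meta to a chloro group and para to a large group gives a 3.1-fold higher number from compound 1 to compound 4 (0.49 log units; beyond the scatter), and the earlier step, a 2.2-fold higher number from compound 1 to compound 3 (0.34 log units; beyond the scatter), runs in the same direction, so among these compounds the rise on adding a second chloro holds at two places on the ring. Compound 3 gives 4770 nM and compound 4 gives 6740 nM, two values within the scatter of each other, so this assay does not separate the two placements of the second chloro. Nothing shown bears on the reason for the rise at this position.

Going by these compounds, it remains open whether the rise belongs to chloro itself or would also follow from another group at this carbon, such as fluoro, methoxy or an amine, a question sharpened by the lower number for fluoro in place of chloro in a 2.1-fold lower number from compound 1 to compound 2 (0.33 log units; beyond the scatter). Also open, on these data alone, is whether the same step keeps its direction when the chain joining the two rings is replaced by a longer chain.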